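The source may report more compounds than this note shows. Statements on the series, on what has been measured and on what is new or still open speak of the compounds shown alone.

Of the compounds shown here, three have been measured.

Compound 1 `c1ccc2c(-c3cn4ccnc4c(-c4ccc5ncn(C6CCCCC6)c5c4)n3)cccc2c1` gives 6.92% in a functional assay on SR cells (Homo sapiens) for inhibition, read by sulforhodamine B assay, with a stated time of 48 h, tested at 10 uM; a lower number here means less inhibition, a higher number more inhibition at the concentration tested (going by the name of the read-out).
Compound 2 `c1ccc(Cn2cnc3ccc(-c4nc(-c5cccc6ccccc56)cn5ccnc45)cc32)cc1` gives 12.4%.
Compound 3 `c1cn2cc(-c3ccc4c(c3)ncn4C3CCCCC3)nc(-c3ccc4ncn(C5CCCCC5)c4c3)c2n1` gives 50%.

Compound 1 and compound 2 differ by benzyl in place of cyclohexyl on an aromatic nitrogen, and this change gives a number 5.5 percentage points higher from compound 1 to compound 2 (within the scatter). Compound 3 carries a different core from compound 1; how the two cores differ is not broken down here. Compound 4 `c1ccc(Cn2cnc3ccc(-c4nc(-c5ccc6c(c5)ncn6C5CCCCC5)cn5ccnc45)cc32)cc1` is built from compound 3 by the same change, (benzyl in place of cyclohexyl on an aromatic nitrogen), at the same kind of place. Because a number 5.5 percentage points higher from compound 1 to compound 2 (within the scatter) stayed within the scatter, a step of about a number 2 percentage points higher from compound 3 to compound 4 (within the scatter) is expected from compound 3 to compound 4. Compound 4 is therefore estimated to give 52%, with a likely range from 30% to 72%; this estimate rests on one step only, and the outcome may differ.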

Compound 4, a percentage reported as inhibition, at one concentration (the size of the read-out at that concentration, not a potency): 94.6%
For compound 4 the middle estimate is 42.6 percentage points below the measured one; the measured number lies above the stated range.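

In this assay, benzyl in place of cyclohexyl on an aromatic nitrogen gives a number 44.6 percentage points higher from compound 3 to compound 4 (beyond the scatter). Going by these compounds alone, the size of this change therefore does not carry over from one core to another: the same change on two cores in this assay, a number 5.5 percentage points higher (within the scatter) from compound 1 to compound 2 and a number 44.6 percentage points higher (beyond the scatter) from compound 3 to compound 4, 39.1 percentage points apart, beyond the scatter of two such steps With only two pairs, this shows that the effect of the swap depends on the core it is made on, but not why, and a reading at a single concentration is not a potency.

The compounds shown leave open how other groups on this nitrogen would behave, such as a longer alkyl chain or a chain ending in an amine. They also leave open whether either step would hold on a third core.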